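The source may report more compounds than this note shows. Statements on the series, on what has been measured and on what is new or still open speak of the compounds shown alone.

Working notes on the series. The shared core of compound 1 `N#Cc1c(-c2ccc(Oc3ccccc3)cc2)ccn2c(CC(F)(F)F)cnc12` carries a phenoxy group on the aryl ring; in a functional assay on CHO cells with metabotropic glutamate receptor 2 (Homo sapiens) as the target, read by GTPgammaS binding (on this read-out higher numbers stand for an effect only at larger amounts of compound and lower numbers for an effect already at smaller amounts), compound 1 gives 186 nM. Among the measured compounds shown here, the only other measured member, compound 2 `N#Cc1c(-c2ccc(NC3CC3)c(Cl)c2)ccn2c(CC(F)(F)F)cnc12`, gives 141 nM in this assay; the two numbers sit within the usual scatter of each other, so no order between compound 1 and compound 2 can be read from them. Compound 1 thus stands at one end of a pair whose values are not separable.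

Compound 3 `N#Cc1c(-c2ccc(N3CCCCC3)cc2)ccn2c(CC(F)(F)F)cnc12` is not yet measured. Its difference from compound 1 is piperidin-1-yl in place of phenoxy on an aromatic carbon, on an aromatic carbon para to a large group. For the measured compounds named here, no measured pair isolates this change, and compound 2 shows only that a nitrogen-linked substituent at that position is compatible with a value of the same order. The step from compound 1 to compound 3 in this assay is therefore expected to be small, at most a slight move toward lower numbers and likely within the scatter, a 1.2-fold lower number from compound 1 to compound 3 (0.09 log units; within the scatter). For compound 3 the estimate in this assay is 150 nM, with a range from 50 nM to 450 nM.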

Compound 3, half-maximal effective concentration: 234 nM
Estimate against measurement, compound 3: 1.6-fold (0.19 log units) below, and the stated range covers the measured number.
By their numbers in this assay, from the lowest: compounds 2, 1 and 3 (each within the scatter of the next).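

In this assay, among the compounds shown here, piperidin-1-yl in place of phenoxy on an aromatic carbon para to a large group gives a 1.3-fold higher number from compound 1 to compound 3 (0.10 log units; within the scatter), and this is the first pair to isolate a single change at this position. The read-out therefore does not separate the two groups here, even though the ring that leaves is aromatic and of carbon only, while the ring that enters is non-aromatic with a hetero atom, and the two groups have the same hydrogen-bond donor and acceptor counts. No measurement is available that could account for this lack of separation.

The compounds shown leave open whether a group of another kind on this carbon, such as a carboxylic acid, a primary amine or a longer alkyl chain, would give a step beyond the scatter. Compound 2 differs from compound 1 and from compound 3 in more than one place, so the contribution of its chlorine and of its nitrogen-linked group cannot be read separately.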